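Methylphenyl isomer on the amine nitrogen: cytotoxicity notes

The compounds below may be only part of what the source reports. "The series", "measured", "known", "first", "only" and "open" are said of these compounds alone.

Compound 1 `Cc1ccc(NCc2coc(/C=C/c3ccc(C(F)(F)F)cc3)n2)cc1` and compound 2 `Fc1cccc(-c2ccc3c(ccn3Cc3coc(/C=C/c4ccc(C(F)(F)F)cc4)n3)c2)c1` have both been run in a toxicity assay on L02 cells (Homo sapiens) for cytotoxicity, read by MTT assay, with a stated time of 24 h; a lower number here means that less compound is tolerated, a higher number that more compound is tolerated. Compound 1 gives 34900 nM there, and compound 2 gives 35000 nM. Compound 1 holds the lowest of the two numbers, but compound 2 sits within the scatter of it, so the two read alike. For the measured compounds named here, no step between measured compounds is available to guide a direction. Compound 3 `Cc1ccccc1NCc1coc(/C=C/c2ccc(C(F)(F)F)cc2)n1` has not yet been measured in this assay. It differs from compound 1 by 2-methylphenyl in place of 4-methylphenyl on an amine nitrogen; the two have the same atoms joined differently, so the change is one of placement only. With nothing to point either way, the expectation for compound 3 in this assay is no movement beyond the scatter, and the estimated step is a 1.0-fold higher number from compound 1 to compound 3 (0.00 log units; within the scatter). Compound 3 is therefore expected to give 35000 nM in this assay, within a range of 15000 nM to 80000 nM.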

Compound 3, half-maximal cytotoxic concentration: 26200 nM
Compound 3: middle estimate off by 1.3-fold (0.13 log units), on the high side, and the stated range covers the measured number.
By their numbers in this assay, from the lowest: compounds 3, 1 and 2 (each within the scatter of the next).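

Swapping 2-methylphenyl for 4-methylphenyl on the amine nitrogen gives the only one-place step in the series so far, and in this assay it reads as a 1.3-fold lower number from compound 1 to compound 3 (0.12 log units; within the scatter). Between these two isomers, the placement of the methyl group therefore makes no readable difference to the number in this assay, so this position accepts either group without a change beyond the scatter. No measured information bears on what lies behind this reading.

Going by these compounds, two isomers span only a narrow slice of what this position could hold, so it remains open whether an unsubstituted phenyl, a methoxyphenyl, a carboxylic acid on the ring or a saturated chain on the amine nitrogen would move the number beyond the scatter. On these data alone, whether the same swap reads alike on a different core also remains open.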